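A Single Stereocentre Inverted at a Saturated Ring Carbon

The compounds below may be only part of what the source reports. "The series", "measured", "known", "first", "only" and "open" are said of these compounds alone.

Compound 1 `CCOC(=O)[C@]1(C(=O)NCc2ccc(C)cc2)C[C@H]1c1cc(OC)c(OC)c(OC)c1`: > 100000 nM in a functional assay on K562 cells (Homo sapiens) for cytotoxicity, read by MTT assay, with a stated time of 48 h; on this read-out higher numbers stand for weaker inhibition and lower numbers for stronger inhibition
Compound 2 `COc1cc([C@@H]2C[C@]2(CO)C(=O)NCc2ccc(C)cc2)cc(OC)c1OC`: > 100000 nM in this assay
Compound 3 `COc1cc([C@@H]2C[C@]2(CO)C(=O)Nc2ccccc2)cc(OC)c1OC`: > 100000 nM in this assay

In this assay compound 1 gives > 100000 nM, which is a limit of the assay and not a number. In this assay compound 2 likewise gives > 100000 nM, again a limit. In this assay compound 3 gives > 100000 nM, also a limit. Because (the limit of > 100000 nM in this assay, at which 3 of the 3 values shown sit), none of the three values is a measured number, and the step that the two limits leave unreadable from compound 1 to compound 2 as well as the step that the two limits leave unreadable from compound 2 to compound 3 cannot be read for size or direction. Compound 2 therefore stands only at a limit, with no measured neighbour on either side.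

The account now follows compound 2 to compound 4 `COc1cc([C@@H]2C[C@@]2(CO)C(=O)NCc2ccc(C)cc2)cc(OC)c1OC`. The change is the two compounds have the same atoms and bonds and differ only in configuration as drawn: 1 of 2 stereo elements differ; a stereocentre at a saturated ring carbon is drawn S in compound 2 and R in compound 4. For the measured compounds named here, no measured step in this set involves a change of configuration alone, so none bears directly on it; the two steps around compound 2 are unreadable. The expectation for compound 4 is therefore a step of unreadable size, most likely leaving it at the same limit: a number no higher from compound 2 to compound 4 (the limit leaves the size open) is expected. Compound 4 is estimated at 100000 nM, within 30000 nM to 300000 nM.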

Compound 4, half-maximal inhibitory concentration: > 100000 nM
Compound 4: only a limit was reported (the forecaster's own chance of this, stated with the estimate: 80%); the middle value sits exactly at the limit.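

In this assay compound 4 gives > 100000 nM, a limit of the assay and not a number. For the compounds shown here, compound 2 also stands at a limit, and no step from compound 2 to compound 4 can be read. The compounds shown leave open whether this change of configuration affects cytotoxicity at all.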